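The compounds below may be only part of what the source reports. "The series", "measured", "known", "first", "only" and "open" are said of these compounds alone.

Compound 2 `COc1cc(-c2nn(-c3cccc(NC(=O)c4ccc(Cl)c(C(F)(F)F)c4)c3)cc2-c2ccncc2)ccc1Cl` is the amide of the series. In a functional assay on SK-MEL-28 cells (Homo sapiens) for inhibition, read by sulforhodamine B assay, with a stated time of 48 h (on this read-out higher numbers stand for weaker inhibition of growth and lower numbers for stronger inhibition of growth), compound 2 gives only a limit, > 32500 nM, which is the limit of > 32500 nM in this assay, at which 1 of the 2 values shown sits, and so no number at all. Its companion, compound 1 `COc1cc(-c2nn(-c3cccc(NC(=O)Nc4ccc(Cl)c(Cl)c4)c3)cc2-c2ccncc2)ccc1Cl`, is the corresponding urea; in this assay compound 1 gives 7320 nM. Among the compounds with values here, the one measured step joining them, an at least 4.4-fold higher number from compound 1 to compound 2 (0.64 log units; beyond the scatter), therefore shows that exchanging the urea for the amide weakened growth inhibition. The full size of that weakening is not known. Compound 2 gave only a limit in this assay.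

Compound 3 `COc1cc(-c2nn(-c3cccc(NC(=O)Nc4ccc(Cl)c(C(F)(F)F)c4)c3)cc2-c2ccncc2)ccc1Cl` now reverses that exchange on the trifluoromethyl-bearing ring: (4-chloro-3-(trifluoromethyl)phenyl)amino in place of 4-chloro-3-(trifluoromethyl)phenyl on a carbonyl carbon. Within the data shown here, this is the mirror image of the only step on record, so the urea hydrogen-bond donor that was lost between compound 1 and compound 2 is restored. A return toward the neighbourhood of compound 1 is expected, and a step of an at least 4.6-fold lower number from compound 2 to compound 3 (0.66 log units; beyond the scatter) is estimated for this assay. For compound 3 the estimated value in this assay is 7000 nM, with a likely span from 2500 nM to 20000 nM.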

Compound 3, concentration for total growth inhibition: 5010 nM
Compound 3: middle estimate off by 1.4-fold (0.15 log units), on the high side; measured number inside the range.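

Within the data shown here, compound 3 gives the first comparison of urea and amide on the same aryl group, the 4-chloro-3-(trifluoromethyl)phenyl group, whereas the earlier step changed the linker and the ring substituent together. In this assay, adding the amino nitrogen on the carbonyl carbon gives an at least 6.4-fold lower number from compound 2 to compound 3 (0.81 log units; beyond the scatter), while trifluoromethyl in place of chloro on an aromatic carbon gives a 1.5-fold lower number from compound 1 to compound 3 (0.16 log units; within the scatter), so the urea linker, and not the exchange of chloro for trifluoromethyl, accounts for the difference seen among these three compounds. The urea-to-amide change can be sized only as a bound, because compound 2 gave a limit and not a number: the limit of > 32500 nM in this assay, at which 1 of the 3 values shown sits.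

The compounds shown do not settle whether the urea nitrogen's hydrogen is itself what matters, a question that a methyl group on that nitrogen or a thiourea in place of the urea would address. They also leave open whether this tolerance at the chloro position extends to other groups on that aromatic carbon, such as a methoxy group or a nitrile.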